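Removing a Ring Methyl: One Change on Two Cores

The compounds below may be only part of what the source reports. "The series", "measured", "known", "first", "only" and "open" are said of these compounds alone.

Compound 1 `COc1ccc(C(=O)/C=C\Nc2ccc(-c3nc4cc(OC)c(OC)c(OC)c4s3)cc2C)cc1[N+](=O)[O-]` and compound 2 `COc1ccc(C(=O)/C=C\Nc2ccc(-c3nc4cc(OC)c(OC)c(OC)c4s3)cc2)cc1[N+](=O)[O-]` share one core and differ in a single spot. In a functional assay on HeLa cells (Homo sapiens) for antiproliferative activity, read by sulforhodamine B assay, with a stated time of 48 h (a higher number here means a weaker inhibitor, a lower number a stronger inhibitor), compound 1 gives 13400 nM, and compound 2 gives 11400 nM. The change between them, (hydrogen in place of methyl on an aromatic carbon), made a step of a 1.2-fold lower number from compound 1 to compound 2 (0.07 log units; within the scatter).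

Compound 3 `COc1ccc2nc(-c3ccc(N/C=C\C(=O)c4cc(OC)c(OC)c(OC)c4Br)c(C)c3)sc2c1` is built on a different core; how the two cores differ is not broken down here. In this assay compound 3 gives 13400 nM, level with compound 1 at the digits shown. Compound 4 `COc1ccc2nc(-c3ccc(N/C=C\C(=O)c4cc(OC)c(OC)c(OC)c4Br)cc3)sc2c1` has not yet been measured. It differs from compound 3 by hydrogen in place of methyl on an aromatic carbon. Going by the values given here, this is the same kind of change as the one from compound 1 to compound 2, though the surroundings are not identical: in compound 3 the carbon is meta to a 6-methoxy-1,3-benzothiazol-2-yl group, whereas in compound 1 it is meta to a large group.

Because the earlier change gave a 1.2-fold lower number from compound 1 to compound 2 (0.07 log units; within the scatter), a step within the scatter, the expected step here is similarly small, estimated at a 1.2-fold lower number from compound 3 to compound 4 (0.07 log units; within the scatter). The estimate for compound 4 is 11500 nM, expected to fall between 6000 nM and 22000 nM.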

Compound 4, half-maximal inhibitory concentration: 8020 nM
For compound 4 the middle estimate is 1.4-fold (0.16 log units) above the measured one, within the range that was stated.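

In this assay, putting hydrogen in place of methyl on the second core made a step of a 1.7-fold lower number from compound 3 to compound 4 (0.22 log units; within the scatter). Set beside the step on the first core, the new result agrees with the earlier one: the same change on two cores in this assay, a 1.2-fold lower number (0.07 log units; within the scatter) from compound 1 to compound 2 and a 1.7-fold lower number (0.22 log units; within the scatter) from compound 3 to compound 4, 1.4-fold (0.15 log units) apart, within the scatter of two such steps. The change therefore carried from one core to the other without a detectable difference, but both steps lie within the scatter, so the pair does not show that removing the methyl really lowers the number, and two cores are too few to support a rule for the whole series.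

The compounds shown leave open what other groups on this aromatic carbon would do, such as a chlorine atom, a methoxy group or an amine, and whether any of them would give a step beyond the scatter. They also leave open whether the two cores would still respond alike to such a group.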